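A fluoro to chloro swap on compound 2

A few compounds are considered here, and "the series" means these few. Any claim that something is new, unique, unknown or untested is made for them only; others in the source may bear on it.

Among the compounds with values here, in an ADME assay on MCF-10A cells (Homo sapiens) for cytotoxicity, read by MTT assay, with a stated time of 48 h (a lower number here means a stronger inhibitor, a higher number a weaker inhibitor), compound 2 `N#Cc1ccc(OCc2nnc(-c3ccc(F)cc3)o2)cc1F` gives 84200 nM, the only true number so far. Compound 1 `COc1ccc(-c2nnc(COc3ccc(C#N)c(F)c3)o2)cc1` reads > 100000 nM, which is a limit of the assay and not a number. Compound 3 `N#Cc1ccc(OCc2nnc(-c3ccc(Cl)cc3)o2)cc1F` has not been measured. It carries chloro in place of fluoro on an aromatic carbon, para to a large group (chloro in place of fluoro on an aromatic carbon). Within the data shown here, the one measured step at this same place is an at least 1.1-fold lower number from compound 1 to compound 2 (0.07 log units; that floor lies within the scatter), where fluoro replaces methoxy. From the compounds shown here alone, compound 1 sits at the limit of > 100000 nM in this assay, at which 1 of the 2 values shown sits, so the true size of that step stays open. Among the measured compounds shown here, no measured step tests chloro itself, so no shift beyond the scatter is expected in this assay. The expected change is a 1.4-fold lower number from compound 2 to compound 3 (0.15 log units; within the scatter). For compound 3 the estimated value is 60000 nM, with an expected range of 25000 nM to 100000 nM.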

Compound 3, half-maximal inhibitory concentration: > 100000 nM
Compound 3 gave a limit, no number; the forecaster's own chance of this, stated with the estimate: 25%; middle value at least 1.6-fold (0.22 log units) away from the limit.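

In this assay the change from 4-fluorophenyl to 4-chlorophenyl gives an at least 1.1-fold higher number from compound 2 to compound 3 (0.07 log units; that floor lies within the scatter) and so shows no stronger inhibition with chloro at this carbon, although only a floor on the step can be read. Both compound 1 and compound 3 are limits, so the step between them cannot be read. Of the three groups seen at this carbon, only fluoro, in compound 2, gives a true number, while the other two compounds sit at the assay's limit: (the limit of > 100000 nM in this assay, at which 2 of the 3 values shown sit).

From the compounds shown here alone, the true size of the fluoro to chloro step remains open, and so does whether chloro differs from fluoro here at all. Also open, going by these compounds, is whether an amine or a carboxylic acid on this aromatic carbon would give a readable number in this assay.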